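Methyl to Hydrogen on an Amide-Type Nitrogen

The source may hold more compounds than are shown below. What is called first, only, known or untested is meant among the compounds shown, and "the series" means these compounds.

Compound 1 `CC1CN(C(N)=S)N=C1c1ccc(F)cc1`: 40%
Compound 2 `CNC(=S)N1CC(C)C(c2ccccc2)=N1`: "not active" (no number reported)

Of the compounds shown here, two have been measured in an in vitro assay on cells for inhibition of Amine oxidase [flavin-containing] A (Homo sapiens), read by Amplex Red, with a stated time of 15 min, tested at 100 uM; a higher number here means more inhibition at the concentration tested (going by the name of the read-out), a lower number less inhibition. Compound 1 gives 40% in this assay, the only numerical read-out so far. Compound 2 is reported in this assay as "not active" (no number reported), without a number; it therefore stands below anything that can be placed on a scale, and no ordering relative to compound 1 can be stated beyond the fact that compound 1 returned a figure and compound 2 did not.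

The step under consideration leads from compound 2 to compound 3 `CC1CN(C(N)=S)N=C1c1ccccc1`. The change is hydrogen in place of methyl on an amide-type nitrogen, that is, methylamino becomes amino on the thiocarbonyl carbon. Since compound 2 has no number, the size of this step cannot be anchored, but the account expects a move upward in this assay, plausibly beyond the usual scatter, towards the range where compound 1 sits.

On that basis compound 3 is estimated at 25% in this assay, within a range from 0% to 50%.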

Compound 3, a percentage reported as inhibition, at one concentration (the size of the read-out at that concentration, not a potency): "not active" (no number reported)
For compound 3 the study gives words and no number; there is nothing to compare the estimate with.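

Neither compound 2 nor compound 3 carries a number in this assay, so no step can be read from the change of methylamino to amino. No further evidence bears on this result. The compounds shown leave open whether this change alters inhibition at all, and how much activity, if any, either compound retains.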